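Swapping the pyrrole hydrazone of compound 3 for cyclopentyl

The source may report more compounds than this note shows. Statements on the series, on what has been measured and on what is new or still open speak of the compounds shown alone.

Three hydrazone analogues sharing one core have been measured in an assay on CHO-K1 cells for displacement of a labelled ligand from adenosine receptor A1 (Homo sapiens), read by scintillation counting, with a stated time of 60 min; a higher number here means a weaker inhibitor, a lower number a stronger inhibitor. Compound 1 `CCOc1cc(/C=N/Nc2nc(N)c3ncn([C@@H]4O[C@H](CO)[C@@H](O)[C@H]4O)c3n2)ccc1O` gives 6940 nM, compound 2 `Nc1nc(N/N=C/c2ccc(Br)cn2)nc2c1ncn2[C@@H]1O[C@H](CO)[C@@H](O)[C@H]1O` gives 4.7 nM, and compound 3 `Nc1nc(N/N=C/c2ccc[nH]2)nc2c1ncn2[C@@H]1O[C@H](CO)[C@@H](O)[C@H]1O` gives 8 nM. The steps of a 1500-fold lower number from compound 1 to compound 2 (3.17 log units; beyond the scatter) and an 870-fold lower number from compound 1 to compound 3 (2.94 log units; beyond the scatter) are large, whereas a 1.7-fold higher number from compound 2 to compound 3 (0.23 log units; within the scatter) is within the scatter, so compound 3 sits close to compound 2 and far from compound 1. Compound 4 `Nc1nc(N/N=C/C2CCCC2)nc2c1ncn2[C@@H]1O[C@H](CO)[C@@H](O)[C@H]1O` differs by cyclopentyl in place of 1H-pyrrol-2-yl on a carbon with a double bond to nitrogen. Within the data shown here, no measured step exchanges an aromatic ring for a saturated one, so the two large steps only show that the attached ring matters greatly. A weakening step is therefore expected, a 7.5-fold higher number from compound 3 to compound 4 (0.88 log units; beyond the scatter), and compound 4 is estimated at 60 nM, between 8 nM and 500 nM.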

Compound 4, inhibition constant: 5.6 nM
Estimate against measurement, compound 4: 11-fold (1.03 log units) above; the whole stated range lies above it.
By their numbers in this assay, from the lowest: compounds 2, 4 and 3 (each within the scatter of the next); then compound 1.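

Replacing an aromatic ring that carries a hydrogen-bond donor with a carbon-only non-aromatic ring leaves the result in this assay within the scatter, with a 1.4-fold lower number from compound 3 to compound 4 (0.15 log units; within the scatter) and a 1.2-fold higher number from compound 2 to compound 4 (0.08 log units; within the scatter). Among these compounds, then, neither an aromatic ring nor that donor is required on this carbon with a double bond to nitrogen, and 3-ethoxy-4-hydroxyphenyl alone stands apart, with a 1200-fold lower number from compound 1 to compound 4 (3.09 log units; beyond the scatter). No measured evidence explains this result. Going by these compounds, whether a methyl group, an open pentyl chain or an amine would give a similar number remains open.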